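The compounds below may be only part of what the source reports. "The series", "measured", "known", "first", "only" and "open" are said of these compounds alone.

Measured compounds:
Compound 1 `CNC(=O)c1cccc(C#Cc2ccccc2Nc2ncnc3ccc(Cl)nc23)c1` — 4900 nM in an assay on isolated protein for inhibition of MAP kinase-interacting serine/threonine-protein kinase 2 (Homo sapiens), read by HTRF, in the presence of a further agent that is not named here; on this read-out higher numbers stand for weaker inhibition and lower numbers for stronger inhibition
Compound 2 `COC(=O)c1oc2ccc(Nc3ncnc4ccc(Cl)nc34)cc2c1C` — 4800 nM in this assay

Compound 2 and compound 1 give numbers that lie within the scatter of each other, so neither can be put ahead of the other. Compound 3 `Cc1c(C(=O)N2CCNCC2)oc2ccc(Nc3ncnc4ccc(Cl)nc34)cc12` carries piperazin-1-yl in place of methoxy on a carbonyl carbon. No measured pair separates an ester from an amide on this core, so the size and direction of the step rest on no shown comparison. The expected step is a 1.6-fold lower number from compound 2 to compound 3 (0.20 log units; within the scatter), small and not clearly beyond the scatter, with a slight lean toward a lower number. Compound 3 is expected to give about 3000 nM, in the range 600 nM to 15000 nM.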

Compound 3, half-maximal inhibitory concentration: 1900 nM
Compound 3: middle estimate off by 1.6-fold (0.20 log units), on the high side, within the range that was stated.
By their numbers in this assay, from the lowest: compound 3; then compounds 2 and 1 (each within the scatter of the next).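

At the carbonyl carbon of the shared core, piperazin-1-yl in place of methoxy gives a 2.5-fold lower number from compound 2 to compound 3 (0.40 log units; beyond the scatter) in this assay, a step beyond the scatter. For the compounds shown here, this is the first comparison at this position, and it shows that an ester need not be kept there and that a six-membered non-aromatic ring is accepted. Nothing measured accounts for the step. Still open, as far as these compounds go, is whether morpholin-4-yl or 4-methylpiperazin-1-yl on the same carbonyl carbon keeps this step. A carboxylic acid or a simple dimethylamide there also remains untested in the compounds shown.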